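Shifting the ester and adding a methoxy on the aniline ring

The compounds below may be only part of what the source reports. "The series", "measured", "known", "first", "only" and "open" are said of these compounds alone.

Of the compounds shown here, two built on a shared core have been tested in a functional assay on HCT-116 cells (Homo sapiens) for cytotoxicity, read by sulforhodamine B assay, with a stated time of 72 h; a lower number here means a stronger inhibitor, a higher number a weaker inhibitor. Compound 1 `CCS(=O)(=O)Nc1cc(-c2ccc3ncnc(Nc4ccc(F)cc4)c3c2)cnc1OC` gives 3160 nM. Among the measured compounds shown here, compound 2 `CCS(=O)(=O)Nc1cc(-c2ccc3ncnc(Nc4cccc(C(=O)OC)c4)c3c2)cnc1OC` gives 400 nM, the lowest of the two numbers; the only measured step, a 7.9-fold lower number from compound 1 to compound 2 (0.90 log units; beyond the scatter), was brought about by putting 3-(methoxycarbonyl)phenyl in place of 4-fluorophenyl on a nitrogen on an aromatic ring.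

Compound 3 `CCS(=O)(=O)Nc1cc(-c2ccc3ncnc(Nc4ccc(C(=O)OC)c(OC)c4)c3c2)cnc1OC` is not yet measured. It differs from compound 2 in one place: 3-methoxy-4-(methoxycarbonyl)phenyl in place of 3-(methoxycarbonyl)phenyl on a nitrogen on an aromatic ring. For the measured compounds named here, the single measured step bears on it only loosely, since that step exchanged one ring substituent pattern for another, while here the 3-(methoxycarbonyl)phenyl of compound 2 is replaced by a ring carrying both a methoxy and a methoxycarbonyl group. Going by the values given here, no measured pair shows what such a change does on this core, so no clear direction can be read from the data, and a step of modest size either way, or none beyond the scatter, is the expectation in this assay.

Compound 3 is therefore estimated at 650 nM, with a range from 150 nM to 2800 nM, which means an expected step of a 1.6-fold higher number from compound 2 to compound 3 (0.21 log units; within the scatter).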

Compound 3, half-maximal inhibitory concentration: 1690 nM
For compound 3 the middle estimate is 2.6-fold (0.41 log units) below the measured one; the measured number falls inside the stated range.
By their numbers in this assay, from the lowest: compound 2; then compounds 3 and 1 (each within the scatter of the next).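

In this assay, replacing the 3-(methoxycarbonyl)phenyl on the nitrogen with 3-methoxy-4-(methoxycarbonyl)phenyl gives a 4.2-fold higher number from compound 2 to compound 3 (0.63 log units; beyond the scatter), so this position does not tolerate every ring that carries a methoxycarbonyl group equally well. Measured against the 4-fluorophenyl ring, the same new ring gives a 1.9-fold lower number from compound 1 to compound 3 (0.27 log units; within the scatter), which means that a methoxycarbonyl group on the ring is not enough on its own to reach the lower number of compound 2. No measurement here gives a reason for this result.

The compounds shown leave open how much of the step from compound 2 belongs to the added methoxy and how much to the change from a 3-(methoxycarbonyl) to a 4-(methoxycarbonyl) pattern, as no ring here carries only one of those two changes. Also open, from the compounds shown here alone, is how this position would respond if a carboxylic acid or an amide took the place of the methyl ester, or if an ethoxy group took the place of the added methoxy.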